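Compound 2 Loses Its Ring: Estimating Compound 3

A few compounds are considered here, and "the series" means these few. Any claim that something is new, unique, unknown or untested is made for them only; others in the source may bear on it.

In an ADME assay on the whole organism (strain CD-1) for metabolic stability, with Mus musculus as the target, at a dose of 3 mg/kg by the intravenous route (a higher number here means that the compound lasts longer, a lower number that the compound disappears faster), compound 1 `CC(CCCCOc1ccccc1CN(C)C(=O)c1ccc(-c2ccco2)cc1)C(=O)O` gives 2.8 h and compound 2 `CN(Cc1ccccc1OCCC[C@@H]1C[C@H]1C(=O)O)C(=O)c1ccc(-c2ccco2)cc1` gives 3.5 h. Within the data shown here, these are the only two numbers so far, and they lie within the scatter of each other, so compound 2 stands level with compound 1. Compound 3 `C/C(=C\CCCOc1ccccc1CN(C)C(=O)c1ccc(-c2ccco2)cc1)C(=O)O` has not yet been measured. It has the same atoms as compound 2, joined differently: 2-carboxyprop-1-en-1-yl in place of 2-carboxycyclopropyl on a saturated chain carbon, three bonds along the chain from an oxygen on an aromatic ring. Among the measured compounds shown here, no measured compound carries the 2-carboxyprop-1-en-1-yl group, so the evidence is thin. For the measured compounds named here, the one measured step at this place, a 1.3-fold higher number from compound 1 to compound 2 (0.10 log units; within the scatter), put 2-carboxycyclopropyl in place of 2-carboxypropyl and lies within the scatter, so no change beyond the scatter is expected in this assay. The estimated step is a 1.2-fold lower number from compound 2 to compound 3 (0.07 log units; within the scatter), which is expected to stay within the scatter. For compound 3 the estimated half-life is 3 h, with an expected range from 1.5 h to 6 h.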

Compound 3, half-life: 1.2 h
Estimate against measurement, compound 3: 2.5-fold (0.40 log units) above; the measured number lies below the stated range.
By their numbers in this assay, from the lowest: compound 3; then compounds 1 and 2 (each within the scatter of the next).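

In this assay, this place on the saturated chain, three bonds along the chain from an oxygen on an aromatic ring, now shows a change beyond the scatter: 2-carboxyprop-1-en-1-yl in place of 2-carboxycyclopropyl gives a 2.9-fold lower number from compound 2 to compound 3 (0.46 log units; beyond the scatter), and the same group in place of 2-carboxypropyl gives a 2.3-fold lower number from compound 1 to compound 3 (0.37 log units; beyond the scatter). Removing the three-membered ring does not by itself separate the numbers, as compound 1 also has no such ring and the step of a 1.3-fold higher number from compound 1 to compound 2 (0.10 log units; within the scatter) stays within the scatter; among these three compounds, the lower number appears only with the added double bond of 2-carboxyprop-1-en-1-yl. Nothing in the data shown accounts for this fall in half-life.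

Going by these compounds, it remains open whether the lower number follows the double bond as such, its geometry, or the methyl group on it, a question that the opposite double-bond isomer or a 2-carboxyethenyl group would address. On these data alone, it is also open whether the same step would appear with a longer chain or with a tetrazole in place of the carboxylic acid.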